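Swapping a Silicon Group for an Ester Chain

A few compounds are considered here, and "the series" means these few. Any claim that something is new, unique, unknown or untested is made for them only; others in the source may bear on it.

Of the compounds shown here, three sharing one core have been tested so far. Compound 1 `Cc1ncc(CO)c2c(Nc3ccccn3)c(NC(C)C)oc12` and compound 2 `Cc1ncc(CO)c2c(Nc3ccccn3)c(N)oc12` both came back without a number: in a functional assay on HEK293 cells for agonist activity at Toll-like receptor 8 (Homo sapiens), read by reporter gene assay (a lower number here means that less compound is needed, a higher number that more compound is needed for the effect), compound 1 gives "not active" (no number reported), and compound 2 gives "not active" (no number reported). Only compound 3 `Cc1ncc(CO)c2c(Nc3ccccn3)c(NC[Si](C)(C)C)oc12` gave a measurable result. In this assay, among the measured compounds shown here, compound 3 gives 4990 nM, which makes it the only compound among the three with a numerical value, so it is the single point of reference for what follows.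

Compound 4 `Cc1ncc(CO)c2c(Nc3ccccn3)c(NCCC(=O)OC(C)(C)C)oc12` is the next compound to be tested. It differs from compound 3 in one place: a group of 8 heavy atoms (6 carbon, 2 oxygen; no ring) in place of a group of 4 heavy atoms (3 carbon, 1 silicon; no ring), on a saturated chain carbon bound to a nitrogen on an aromatic ring. For the measured compounds named here, no direct step between two measured compounds is available to show how changes at this position move the activity. Compound 1 and compound 2 carry no number at all.

The expectation for compound 4 is therefore anchored on compound 3 alone. Going by the values given here, the step from compound 3 to compound 4 is estimated to be a 1.0-fold higher number from compound 3 to compound 4 (0.00 log units; within the scatter), that is, no change beyond the usual scatter, because compound 3 with 4990 nM is the only measured value and nothing in the data points in either direction. Compound 4 is therefore estimated to give 5000 nM in this assay, within a range of 1500 nM to 20000 nM.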

Compound 4, half-maximal effective concentration: 7640 nM
For compound 4 the middle estimate is 1.5-fold (0.18 log units) below the measured one; measured number inside the range.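

In this assay, among the compounds shown here, the change gives a 1.5-fold higher number from compound 3 to compound 4 (0.18 log units; within the scatter), the first step at this position with a number at both ends. A measurable response therefore does not depend on the group of 4 heavy atoms containing silicon: (tert-butoxycarbonyl)methyl, with 8 heavy atoms and 2 hydrogen-bond acceptors, can stand in its place, on a saturated chain carbon bound to a nitrogen on an aromatic ring, with no difference beyond the scatter. No measurement shown here accounts for this tolerance, and none connects it to any particular feature of either group.

Two very different groups giving matching values still says little about which features matter here, and steps involving the two compounds without a number cannot be read. Going by these compounds, it remains open whether a carboxylic acid in place of the tert-butyl ester, an amine at the end of the chain, a longer chain or a phenyl ring would leave the number where it stands or move it clearly in either direction.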